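What Defined Stereocentres May Do to Compound 1

The source may hold more compounds than are shown below. What is called first, only, known or untested is meant among the compounds shown, and "the series" means these compounds.

In a functional assay on K562 cells (Homo sapiens) for antiproliferative activity, with a stated time of 48 h (a lower number here means a stronger inhibitor, a higher number a weaker inhibitor), compound 1 `Cc1cc(=O)c2c(OCC3CO3)cc(OCC3CO3)cc2o1` gives 6300 nM and compound 2 `Cc1cc(=O)c2c(O)cc(OC[C@@H]3CO3)cc2o1` gives 8030 nM, two values within the usual scatter of each other. Compound 3 `Cc1cc(=O)c2c(OC[C@@H]3CO3)cc(OC[C@H]3CO3)cc2o1` has not yet been measured. It has the same atoms and bonds as compound 1, and the only difference lies in how its stereocentres are drawn: the two compounds have the same atoms and bonds; at least one stereo element is drawn with a configuration in one of them and without one in the other: 2 of 2 stereo elements differ; a stereocentre at a saturated ring carbon is drawn without a configuration in compound 1 and S in compound 3; a stereocentre at a saturated ring carbon is drawn without a configuration in compound 1 and R in compound 3. Among the measured compounds shown here, no measured pair shows what such a change does, so the expectation in this assay rests on compound 1 at 6300 nM, with no shift beyond the scatter. The expected step is a 1.1-fold lower number from compound 1 to compound 3 (0.02 log units; within the scatter). Compound 3 is estimated at 6000 nM, within a range of 2500 nM to 14000 nM.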

Compound 3, half-maximal inhibitory concentration: 1490 nM
Compound 3: middle estimate off by 4.0-fold (0.60 log units), on the high side; the whole stated range lies above it.
By their numbers in this assay, from the lowest: compound 3; then compounds 1 and 2 (each within the scatter of the next).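

With no change in atoms or bonds, drawing both saturated ring carbons with a defined configuration, one S and one R, comes with a real shift in this assay: a 4.2-fold lower number from compound 1 to compound 3 (0.63 log units; beyond the scatter). Compounds 1 and 2 could not show this, as neither pair of measured compounds isolated stereochemistry. So at these two ring carbons, configuration alone is linked to a step beyond the scatter, and the only fact tied to it is this: the fact that one of compounds 1 and 3 is drawn with a defined configuration and the other without, at the place where they differ.

Which of the two stereocentres carries the step remains open, as does the effect of other combinations of configuration. Going by these compounds, it is also open whether an amine in place of either ring would keep this gain.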